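Benzylamide variants on the hydroxyurea alkyne series

The compounds below may be only part of what the source reports. "The series", "measured", "known", "first", "only" and "open" are said of these compounds alone.

Going by the values given here, in an assay for inhibition of Polyunsaturated fatty acid 5-lipoxygenase (Homo sapiens), read by HPLC, with stated times of 15 min and 10 min (on this read-out higher numbers stand for weaker inhibition and lower numbers for stronger inhibition), compound 2 `COc1ccc(CNC(=O)c2cccc(C#CC(C)N(O)C(N)=O)c2)c(C(F)(F)F)c1` gives 1700 nM, the second highest of the three numbers measured so far. Compound 1 `CC(C#Cc1cccc(C(=O)NCc2cccc(F)c2)c1)N(O)C(N)=O` gives 4000 nM, a higher number beyond the scatter, while compound 3 `C[C@H](C#Cc1cccc(C(=O)NCC[C@H](c2ccc(F)cc2)c2ccc(C(F)(F)F)cc2)c1)N(O)C(N)=O` gives 230 nM, a lower number, also beyond the scatter. Compound 4 `CC(C#Cc1cccc(C(=O)NCc2ccccc2C(F)(F)F)c1)N(O)C(N)=O` has not yet been measured in this assay; it differs from compound 2 by hydrogen in place of methoxy on an aromatic carbon. Among the compounds with values here, with no measured pair showing this change, the expected step from compound 2 to compound 4 is a 1.5-fold higher number from compound 2 to compound 4 (0.17 log units; within the scatter), a small weakening that may not exceed the scatter. Compound 4 is therefore estimated at 2500 nM, within a range of 1000 nM to 6000 nM.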

Compound 4, half-maximal inhibitory concentration: 700 nM
For compound 4 the middle estimate is 3.6-fold (0.55 log units) above the measured one, and the stated range ends above it.
By their numbers in this assay, from the lowest: compound 3; then compound 4; then compound 2; then compound 1.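

In this assay hydrogen in place of methoxy on the aromatic carbon meta to a trifluoromethyl group gives a 2.4-fold lower number from compound 2 to compound 4 (0.39 log units; beyond the scatter) as a modest step beyond the scatter. The methoxy group is therefore not needed at this position for inhibition, and the ring bearing trifluoromethyl alone gives the lower number of the pair. Nothing available explains the direction of this step. Open, on these data alone, is how an amine or a carboxylic acid at this carbon would compare with hydrogen and methoxy. Also open, as far as these compounds go, is whether the step holds when the trifluoromethyl group is absent.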